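Notes on compound 4: bromo in place of hydrogen

A few compounds are considered here, and "the series" means these few. Any claim that something is new, unique, unknown or untested is made for them only; others in the source may bear on it.

Measured compounds and values in a functional assay on NCI/ADR cells (Homo sapiens) for inhibition, read by sulforhodamine B assay, with a stated time of 48 h; a lower number here means a stronger inhibitor of growth, a higher number a weaker inhibitor of growth:
compound 1 `O=C1C=COC(/C=C/c2ccccc2)C1` — 105 uM
compound 2 `COc1ccc(/C=C/C2CC(=O)C=CO2)cc1` — 239 uM
compound 3 `COc1ccc(C2CC(=O)C=CO2)cc1` — 420 uM

Compound 3 stands highest of the three numbers in this assay. Its nearest neighbour is compound 2 at 239 uM, which lies within the scatter of the value of compound 3, so no order can be read between those two. The furthest is compound 1, whose 105 uM sits beyond the scatter from compound 3. Among the compounds with values here, the only step between compounds that differ in one place is a 2.3-fold higher number from compound 1 to compound 2 (0.36 log units; beyond the scatter), a methoxy in place of hydrogen on an aromatic carbon.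

Compound 4 `COc1ccc(C2CC(=O)C(Br)=CO2)cc1` differs from compound 3 by bromo in place of hydrogen on a double-bonded ring carbon. Within the data shown here, no measured pair shows bromo in place of hydrogen on a double-bonded ring carbon, and the single measured step concerns a different place on the shared core, so it does not bear on this change. With nothing in the series to anchor a direction, a step within the scatter is the working expectation in this assay. The expected step is a 1.4-fold lower number from compound 3 to compound 4 (0.15 log units; within the scatter). Compound 4 is therefore estimated at 300 uM, with a range from 100 uM to 900 uM.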

Compound 4, concentration for growth inhibition (reported as GI): 52.9 uM
Compound 4: middle estimate off by 5.7-fold (0.75 log units), on the high side; measured number below the stated range.
By their numbers in this assay, from the lowest: compounds 4 and 1 (each within the scatter of the next); then compounds 2 and 3 (each within the scatter of the next).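

In this assay, within the data shown here, bromo in place of hydrogen on a double-bonded ring carbon gives a 7.9-fold lower number from compound 3 to compound 4 (0.90 log units; beyond the scatter), the first step read at this position and the first to lower the number. Among these compounds, the only earlier single-place step, a 2.3-fold higher number from compound 1 to compound 2 (0.36 log units; beyond the scatter), was a methoxy change on an aromatic carbon and raised the number, so it said nothing about the six-membered non-aromatic ring; this result shows that a change on that ring, two ring bonds from the ring oxygen, can move the number beyond the scatter. No measurement in hand accounts for this step.

As far as these compounds go, the step rests on one pair, so it remains open whether bromo at this carbon would lower the number to a similar extent on the core of compound 1 or compound 2. Also open, from the compounds shown here alone, is whether the effect is particular to bromo or extends to other groups at this place, such as chloro, iodo, methyl, nitrile or an amine.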